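The compounds below may be only part of what the source reports. "The series", "measured", "known", "first", "only" and "open" are said of these compounds alone.

In a functional assay on cells (Breast carcinoma cell, Homo sapiens) for cytotoxicity, read by sulforhodamine B assay, with a stated time of 48 h (on this read-out higher numbers stand for weaker inhibition of growth and lower numbers for stronger inhibition of growth), compound 1 `COc1nc2sc(C)cn2c1C=C1C(=O)N(C)c2ccccc21` gives 4820 nM and compound 2 `COc1ccc2c(c1)/C(=C\c1c(OC)nc3sc(C)cn13)C(=O)N2` gives 870 nM on the same read-out. Compound 2 therefore holds the lower of the two numbers, with compound 1 as its nearest neighbour and a gap beyond the usual scatter. Compound 3 `COc1nc2sc(C)cn2c1/C=C1/C(=O)Nc2ccccc21` has no number yet in this assay at this stage. Relative to compound 2, the structural change is hydrogen in place of methoxy on an aromatic carbon in the count, in short hydrogen in place of methoxy on an aromatic carbon. Within the data shown here, no measured pair shows this change alone, so no direct precedent fixes its size or direction. The two measured compounds offer only a working span, with compound 2 at 870 nM as its low end and compound 1 at 4820 nM as its high end. A modest move toward a higher number is expected, estimated as a 2.2-fold higher number from compound 2 to compound 3 (0.34 log units; beyond the scatter) for this change. A result close to compound 2 remains possible. For compound 3 the expected value is 1900 nM as the central estimate, with an estimated range from 600 nM to 5500 nM for repeat measurements.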

Compound 3, concentration for 50% growth inhibition: 2520 nM
Beside the measured number, compound 3's estimate is 1.3-fold (0.12 log units) below it, within the range that was stated.
By their numbers in this assay, from the lowest: compound 2; then compounds 3 and 1 (each within the scatter of the next).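

Among these compounds, replacing methoxy with hydrogen on an aromatic carbon gives a 2.9-fold higher number from compound 2 to compound 3 (0.46 log units; beyond the scatter) in this assay, the first direct reading of this change; the step is modest in size but lies beyond the usual scatter. The position therefore registers on this read-out: what sits on this aromatic carbon, meta to a fused ring and para to a fused ring, moves the number, and methoxy goes with the lower number of this pair. No measured data bear on the reason for the step.

A single pair cannot show whether the lower number belongs to methoxy in particular or whether other groups on this carbon, such as a hydroxyl, an amine, a fluorine or a longer ethoxy chain, would match or pass it. As far as these compounds go, it also remains open whether the same change would produce a step of similar size and direction on the core of compound 1.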